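The source may hold more compounds than are shown below. What is called first, only, known or untested is meant among the compounds shown, and "the series" means these compounds.

Working notes on the series. Compound 1 `O=CNc1ccc(C2=NNC(=O)CC2)cc1` gives 3.74 ug/mL in a functional assay for inhibition, with Homo sapiens as the target; a higher number here means that more compound is needed for the effect, a lower number that less compound is needed. Compound 2 `CC(=O)Nc1ccc(C2=NNC(=O)C(C)C2)cc1`, which carries acetyl instead of formyl on the anilide nitrogen and a methyl on the core, gives 46.4 ug/mL in this assay; of the two numbers available, compound 1 holds the lower one, and the gap to compound 2 lies beyond the scatter. Compound 3 `Nc1cccc(C2=NNC(=O)CC2)c1` gives in this assay only > 46.4 ug/mL, which is a limit of the assay and not a number, namely (the limit of > 46.4 ug/mL in this assay, at which 1 of the 3 values shown sits).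

Compound 4 `O=C1CCC(c2ccc(NC(=O)CCCCl)cc2)=NN1` is not yet measured. It differs from compound 1 by 3-chloropropyl in place of hydrogen on a carbonyl carbon. Among the compounds with values here, no step between measured compounds that differ in one place exists, so the size of the step must be guessed: a rise in the number for this assay is expected, modest rather than large, since compound 2 shows 46.4 ug/mL with a larger acyl group, though compound 2 also differs at the core. The expected change is a 2.7-fold higher number from compound 1 to compound 4 (0.43 log units; beyond the scatter). Compound 4 is estimated at 10 ug/mL, within a range from 2.5 ug/mL to 40 ug/mL.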

Compound 4, half-maximal effective concentration: > 46.4 ug/mL
Compound 4 gave a limit, no number (the forecaster's own chance of this, stated with the estimate: 20%); middle value at least 4.6-fold (0.66 log units) away from the limit.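

On the carbonyl carbon bonded to the amide-type nitrogen, 3-chloropropyl in place of hydrogen gives an at least 12-fold higher number from compound 1 to compound 4 (1.09 log units; beyond the scatter) in this assay and is a large step against this change. Unlike compound 2, which also differs at the core, compound 4 keeps the core of compound 1, so the change is read at this one place alone. The result for compound 4 is a limit of the assay and not a number, which makes the size of the step a lower bound only, and it joins a second compound at that limit: (the limit of > 46.4 ug/mL in this assay, at which 2 of the 4 values shown sit).

Open, as far as these compounds go, is whether the acetyl or the butanoyl group on the unchanged core would keep a number near that of compound 1 (3.74 ug/mL), which would separate chain length from the chlorine. Also open, from the compounds shown here alone, is what an amine or a carboxylic acid in place of the chlorine would give.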